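Removing the Hydroxymethyl from a Propargyl Thioether Side Chain

A few compounds are considered here, and "the series" means these few. Any claim that something is new, unique, unknown or untested is made for them only; others in the source may bear on it.

Measured compounds:
compound 1, `C#CCSc1cnc2ccccc2c1[Se]CC#CCCl`: 0.8 ug/mL
compound 2, `OCC#CCSc1cnc2ccccc2c1SCC#CCCl`: 5.1 ug/mL
compound 3, `OCC#CCSc1cnc2ccccc2c1Cl`: 2.4 ug/mL

Of the compounds shown here, three sharing one core have been tested in a functional assay on P388 cells (Mus musculus) for antiproliferative activity, with a stated time of 72 h; a lower number here means a stronger inhibitor, a higher number a weaker inhibitor. Compound 2 has the highest number of the three: compound 3 lies beyond the scatter below it, and compound 1 gives the lowest number of the set. The unmeasured compound 4, `C#CCSc1cnc2ccccc2c1SCC#CCCl`, arises from compound 2 by a single change: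

hydrogen in place of hydroxymethyl on a triple-bonded carbon

For the measured compounds named here, only one measured step concerns a change at a single site, a 2.1-fold lower number from compound 2 to compound 3 (0.33 log units; beyond the scatter), and it touches the other side chain of the core, so it does not speak to the change in hand. Compound 1 and compound 2 differ in two places, one of them being this same hydroxymethyl, and compound 1 gives the clearly lower number; that hints, without proving it, that compound 4 may also sit below compound 2 in this assay. A modest downward step is therefore expected, a 2.8-fold lower number from compound 2 to compound 4 (0.45 log units; beyond the scatter). Compound 4 is estimated at 1.8 ug/mL, with a range from 0.7 ug/mL to 4.5 ug/mL.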

Compound 4, concentration for 50% inhibition: 3 ug/mL
The estimate for compound 4 lay 1.7-fold (0.22 log units) below the measured number; measured number inside the range.
By their numbers in this assay, from the lowest: compound 1; then compounds 3, 4 and 2 (each within the scatter of the next, the first and the last beyond it).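

In this assay, putting hydrogen in place of hydroxymethyl on the triple-bonded carbon gives a 1.7-fold lower number from compound 2 to compound 4 (0.23 log units; within the scatter), so with the other side chain unchanged, the swap from 3-hydroxyprop-1-yn-1-yl to ethynyl does not separate the two compounds. The earlier comparison of compound 1 with compound 2 could not show this, as they differ in two places and the hydroxymethyl could not be judged apart from the second difference. The remaining difference now stands alone as a 3.8-fold higher number from compound 1 to compound 4 (0.57 log units; beyond the scatter): with ethynyl present in both, the selenium-containing side chain of compound 1 goes with the lower number and the sulfur-containing side chain with the higher one, and no other measurement at hand bears on why either step has the size it does.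

From the compounds shown here alone, whether hydrogen and hydroxymethyl would also stay within the scatter of each other on the selenium-containing side chain remains open. Also open is how an aminomethyl group, a carboxylic acid or a longer alkyl chain on the same triple-bonded carbon would compare with these two, as the compounds shown carry only hydrogen or hydroxymethyl there.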